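The compounds below may be only part of what the source reports. "The series", "measured", "known", "first", "only" and "open" are said of these compounds alone.

Measured compounds in a functional assay on HEK293 cells for agonist activity at G-protein coupled receptor 39 (Homo sapiens), read by scintillation proximity assay and inositol phosphate accumulation, with a stated time of 75 min, in the presence of a further agent that is not named here; on this read-out lower numbers stand for an effect already at smaller amounts and higher numbers for an effect only at larger amounts of compound:

compound 1, `Cc1nn(-c2ncnc3nc[nH]c23)c2c1C(C(=O)NCc1ccc(F)cc1)CC(=O)N2` — 4 nM
compound 2, `C/C(=N\NC(=O)c1cc2ccccc2cc1O)c1ccc(N)cc1` — 1100 nM
compound 3, `Cc1nn(-c2ncnc3nc[nH]c23)c2c1C(OCc1ccccc1C#N)CC(=O)N2` — 8 nM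

Compound 3 stands second highest of the three numbers. Its nearest neighbour is compound 1, whose number lies within the usual scatter of that of compound 3, so the two are not told apart here. Compound 2, which does not share the core of compound 1 and compound 3, gives a number beyond the scatter from compound 3, and compound 3 therefore reads as the lower of that pair.

Compound 4, `Cc1nn(-c2ncnc3nc[nH]c23)c2c1C(OCCn1nccc1C)CC(=O)N2`, keeps the core of compound 3 and differs only in one group: (5-methyl-1H-pyrazol-1-yl)methyl in place of 2-cyanophenyl on a saturated chain carbon bound to an oxygen on a saturated carbon. Among the compounds with values here, no measured pair shows this kind of change, so no step from the data can be carried over. Compound 1 and compound 3 carry different groups at that side and sit within the scatter of each other, which hints that this side tolerates variation, but only within aromatic six-membered groups. The change in compound 4 is larger in kind, and a modest shift toward higher numbers in this assay is expected, with a step of a 3.1-fold higher number from compound 3 to compound 4 (0.49 log units; beyond the scatter) estimated from compound 3 to compound 4. Compound 4 is expected to give 25 nM, with a range of 6 nM to 120 nM.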

Compound 4, half-maximal effective concentration: 10 nM
The estimate for compound 4 lay 2.5-fold (0.40 log units) above the measured number, and the stated range covers the measured number.
By their numbers in this assay, from the lowest: compounds 1, 3 and 4 (each within the scatter of the next, the first and the last beyond it); then compound 2.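

In this assay, the exchange of 2-cyanophenyl for (5-methyl-1H-pyrazol-1-yl)methyl gives a 1.3-fold higher number from compound 3 to compound 4 (0.10 log units; within the scatter) and leaves the two compounds not told apart. This position therefore accepts more than a six-membered aromatic ring of carbon only: a five-membered aromatic ring with 2 hetero atoms serves here as well, and the nitrile is not required for a number in this range, at least in this pair. No measurement at hand bears on why the number holds across this change.

Open, from the compounds shown here alone, is whether a group with no aromatic ring, such as a primary amine or a carboxylic acid, would hold the number at this place. Also open, going by these compounds, are the effect of a longer chain ahead of the pyrazole and the part played by its methyl group.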